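This account rests on a few compounds, and the source may have more. Where it says the series, first, only, none or still open, it means among the compounds named here.

Working notes on the series.

Three compounds have numbers in a functional assay on cells for positive allosteric modulation of G-protein coupled receptor 68 (Homo sapiens), read by a luciferase reporter and cAMP accumulation, with a stated time of 30 min, at pH 6.8 and pH 8.3, in the presence of a further agent that is not named here (a lower number here means a less potent compound, a higher number a more potent compound, by a factor of ten per unit of this negative logarithm), so far. Compound 1 `Nc1nc(NCc2ccccc2)nc(-c2cc(Cl)ccc2CO)n1` gives 4.49 in this assay. Compound 2 `Nc1nc(NCCCCc2ccccc2)nc(-c2ccccc2CO)n1` gives 5.52 in this assay. Compound 3 `Nc1nc(NCCCc2ccccc2)nc(-c2cc(Cl)ccc2CO)n1` gives 5.35 in this assay, which places it second highest of the three: its nearest neighbour is compound 2, whose number is within the scatter of it, and its furthest is compound 1, whose number lies beyond the scatter below it.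

For the measured compounds named here, the one measured step that bears on chain length is a number 0.86 log units higher from compound 1 to compound 3 (beyond the scatter), a modest gain on lengthening the chain by two carbons on the chlorinated core.

Compound 4 `Nc1nc(NCCCCc2ccccc2)nc(-c2cc(Cl)ccc2CO)n1` differs from compound 3 by benzyl in place of phenyl on a saturated chain carbon, three bonds along the chain from a nitrogen on an aromatic ring, that is, one further carbon in the chain. Going by the values given here, compound 2 carries the same four-carbon chain on the unchlorinated core; no step between compound 2 and compound 4 is set out, so only the two numbers can be compared. Compound 2 and compound 3 sit within the scatter of each other, which suggests the extra carbon adds little once the chain already holds three. The expected step is a number 0.15 log units higher from compound 3 to compound 4 (within the scatter), small and not clearly beyond the scatter. Compound 4 is therefore estimated at 5.5 in this assay, with a range from 5.1 to 5.9.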

Compound 4, negative logarithm of the antagonist equilibrium constant: 4.98
The estimate for compound 4 lay 0.52 log units above the measured number, outside the stated range (below it).
By their numbers in this assay, from the lowest: compound 1; then compound 4; then compounds 3 and 2 (each within the scatter of the next).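

With the chloro group present in this assay, the response to chain length does not keep rising: benzyl in place of phenyl on a saturated chain carbon, three bonds along the chain from a nitrogen on an aromatic ring, gives a number 0.37 log units lower from compound 3 to compound 4 (beyond the scatter) and so reverses the direction of the earlier gain. The 3-phenylpropyl group still improves on the shortest chain, with a number 0.49 log units higher from compound 1 to compound 4 (beyond the scatter) as the net result, but compound 3 now stands above both of its chain neighbours among the chloro compounds, so this position shows a peak rather than a steady climb, and nothing at hand accounts for that turn. For the compounds shown here, the first direct reading of the chloro group is also a loss, at a number 0.54 log units lower from compound 2 to compound 4 (beyond the scatter) for chloro in place of hydrogen on an aromatic carbon with the chain held constant.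

As far as these compounds go, whether the chloro group costs the same on the shorter chains remains open, since this one pair holds for a single chain length. Also open, from the compounds shown here alone, is how the position responds to a still longer chain, or to an amine or a carboxylic acid at the end of the chain in place of the phenyl ring.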